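Methyl for Fluoro on the Aryl Ring of Compound 3

The source may report more compounds than this note shows. Statements on the series, on what has been measured and on what is new or still open speak of the compounds shown alone.

Measured compounds:
compound 1, `C=CC(=O)Nc1cccc(Nc2nc(N/N=C/c3ccc(F)cc3F)ncc2Cl)c1`; in an ADME assay on HT-29 cells (Homo sapiens) for inhibition, read by MTT assay, with a stated time of 72 h (on this read-out lower numbers stand for stronger inhibition and higher numbers for weaker inhibition), compound 1 gives 4760 nM
compound 2, `C=CC(=O)Nc1cccc(Nc2nc(N/N=C/c3cn(Cc4ccccc4)c4ccccc34)ncc2Cl)c1`; in this assay compound 2 gives 11000 nM
compound 3, `C=CC(=O)Nc1cccc(Nc2nc(N/N=C(\C)c3ccc(F)cc3)ncc2Cl)c1`; in this assay compound 3 gives 5050 nM

Among these three numbers compound 3 stands second highest. Compound 1 lies within the scatter of it, so the two cannot be ranked; compound 2 lies beyond the scatter, at a higher number than compound 3. For the measured compounds named here, the only step between compounds that differ in one place is a 1.1-fold higher number from compound 1 to compound 3 (0.03 log units; within the scatter), which exchanges one aromatic group for another on a nitrogen and leaves the number essentially unchanged.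

Compound 4, `C=CC(=O)Nc1cccc(Nc2nc(N/N=C(\C)c3ccc(C)cc3)ncc2Cl)c1`, differs from compound 3 by methyl in place of fluoro on an aromatic carbon. Going by the values given here, no measured step tests methyl against fluoro at this position, and the step from compound 1 to compound 3 concerns a different exchange, so it bears on the present one only loosely. With nothing in the data pointing either way, the step of a 1.1-fold higher number from compound 3 to compound 4 (0.04 log units; within the scatter) is expected to stay within the scatter, in no particular direction. Compound 4 is therefore estimated at 5500 nM in this assay, with a range from 2500 nM to 12000 nM.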

Compound 4, half-maximal inhibitory concentration: 3210 nM
Compound 4: middle estimate off by 1.7-fold (0.23 log units), on the high side, within the range that was stated.
By their numbers in this assay, from the lowest: compounds 4, 1 and 3 (each within the scatter of the next); then compound 2.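

In this assay, for the compounds shown here, the exchange of 4-fluorophenyl to 4-methylphenyl gives a 1.6-fold lower number from compound 3 to compound 4 (0.20 log units; within the scatter) and so offers the only direct reading of methyl against fluoro at this place, para to a large group, showing that the two groups cannot be told apart here. The wider exchange on the nitrogen gives a 1.5-fold lower number from compound 1 to compound 4 (0.17 log units; within the scatter) and likewise leaves this pair unranked, so compound 4 joins compound 1 and compound 3 as a set of neighbouring pairs whose printed steps all stay within the scatter. No measurement is available that would account for this reading.

The compounds shown leave open whether a trifluoromethyl, a methoxy, an amine or a carboxylic acid on this same aromatic carbon would carry the number beyond the scatter, as two small groups with a single heavy atom each are all that have been compared here. Also open, from the compounds shown here alone, is whether methyl for fluoro would read the same way on the core of compound 1, or in cells other than those of this assay.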